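The compounds below may be only part of what the source reports. "The series", "measured", "known", "first", "only" and "open" are said of these compounds alone.

Measured compounds:

Compound 1, `CC(C)C(/C=C1\NC(=O)NC1=O)c1ccc(-c2ccc3cccc(F)c3c2)[nH]c1=O`: in a functional assay on CHO cells for antagonist activity at prostaglandin E2 receptor EP3 subtype (Homo sapiens), read by cAMP accumulation, with a stated time of 30 min (a higher number here means a weaker inhibitor, a lower number a stronger inhibitor), compound 1 gives 87 nM.

Compound 2, `CC(C)C(c1ccc(-c2ccc3cccc(F)c3c2)[nH]c1=O)C1SC(=O)NC1=O`: in this assay compound 2 gives 110 nM.

Among the two compounds measured, compound 2 carries the higher number, and the only measured step, a 1.3-fold higher number from compound 1 to compound 2 (0.10 log units; within the scatter), is too small to separate the two. Compound 3, `CC(C)C(c1ccc(-c2ccc3cccc(F)c3c2)[nH]c1=O)C1C(=O)NC(=O)N1C`, has not yet been measured. It differs from compound 2 in one place: 3-methyl-2,5-dioxoimidazolidin-4-yl in place of 2,4-dioxo-1,3-thiazolidin-5-yl on a saturated chain carbon bound to an aromatic carbon and a saturated chain carbon. The step from compound 1 to compound 2 is the only one that bears on this, since it also swaps one five-membered ring bearing two hetero atoms for another at the same place, and it stayed within the scatter. A change of a closely related ring in the same position is therefore expected to move this assay little, in either direction. Compound 3 is estimated at 130 nM, with a range from 50 nM to 350 nM, meaning an expected step of a 1.2-fold higher number from compound 2 to compound 3 (0.07 log units; within the scatter).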

Compound 3, half-maximal inhibitory concentration: 320 nM
Compound 3: the middle estimate sits 2.5-fold (0.39 log units) below what was measured; measured number inside the range.
By their numbers in this assay, from the lowest: compounds 1 and 2 (each within the scatter of the next); then compound 3.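

In this assay, this position on the saturated chain carbon does not treat every five-membered ring with two hetero atoms alike. Placing 3-methyl-2,5-dioxoimidazolidin-4-yl there instead of 2,4-dioxo-1,3-thiazolidin-5-yl gives a 2.9-fold higher number from compound 2 to compound 3 (0.46 log units; beyond the scatter) and the comparison with the first ring gives a 3.7-fold higher number from compound 1 to compound 3 (0.57 log units; beyond the scatter) so both steps are modest but, unlike the earlier step between rings, lie beyond the scatter. No measurement at hand explains this rise in the number.

From the compounds shown here alone, compound 3 differs from compound 2 in both the ring and its methyl group, so whether the ring itself or the methyl group accounts for the rise stays open. Also open, going by these compounds, is how this position would respond to a group of a different kind, such as a carboxylic acid.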